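The compounds below may be only part of what the source reports. "The series", "measured", "known", "first", "only" and "open" are said of these compounds alone.

Compound 1 `CC(C)(C)c1ccc(C(=O)N/N=C/c2ccc([N+](=O)[O-])o2)cc1`: > 200000 nM
Compound 2 `CCCCc1ccc(C(=O)N/N=C/c2ccc([N+](=O)[O-])o2)cc1`: > 200000 nM
Compound 3 `CCCOc1ccc(C(=O)N/N=C/c2ccc([N+](=O)[O-])o2)cc1`: > 200000 nM

These three compounds were tested in an ADME assay on LL24 cells (Homo sapiens) for inhibition, read by MTT assay, with a stated time of 24 h; on this read-out lower numbers stand for stronger inhibition and higher numbers for weaker inhibition. Every entry above is a limit of the assay and not a number, as the limit of > 200000 nM in this assay, at which 3 of the 3 values shown sit, shows. Compound 3 stands at its limit of > 200000 nM.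

Compound 4 `CCCc1ccc(C(=O)N/N=C/c2ccc([N+](=O)[O-])o2)cc1` has propyl in place of propoxy on an aromatic carbon. Two measured changes bear on this one: a step that the two limits leave unreadable from compound 2 to compound 3 and a step that the two limits leave unreadable from compound 1 to compound 3. Neither has a readable size. With a step that the two limits leave unreadable from compound 2 to compound 3 as the closest guide, no step beyond the usual scatter is expected in this assay, and no direction can be named. The expected change is a step that the limit leaves unreadable from compound 3 to compound 4. Compound 4 is estimated at 250000 nM, with an expected range of 120000 nM to 500000 nM.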

Compound 4, half-maximal inhibitory concentration: 89000 nM
The estimate for compound 4 lay 2.8-fold (0.45 log units) above the measured number, and the stated range ends above it.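

In this assay, among these compounds, compound 4 is the first compound here to give a number rather than a limit, and propyl in place of propoxy on the aromatic carbon gives an at least 2.2-fold lower number from compound 3 to compound 4 (0.35 log units; beyond the scatter). The same holds against the butyl and tert-butyl groups, with an at least 2.2-fold lower number from compound 2 to compound 4 (0.35 log units; beyond the scatter) and an at least 2.2-fold lower number from compound 1 to compound 4 (0.35 log units; beyond the scatter). The steps among the first three compounds cannot be read, and each new step has a limit at one end: the limit of > 200000 nM in this assay, at which 3 of the 4 values shown sit.

As far as these compounds go, the true size of each new step therefore stays open. From the compounds shown here alone, what an ethyl group or an amine would give at this place also stays open.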